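A Shorter Acid Swapped for an Amide-Bearing Piperidine

This account rests on a few compounds, and the source may have more. Where it says the series, first, only, none or still open, it means among the compounds named here.

Compound 1 `COc1ccc(/C=C\c2cc(OC)c(OC)c(OC)c2)cc1OCc1ccc(CN2C[C@H](O)C[C@@H]2C(=O)O)cc1` was tested in a functional assay on MC-38 cells (Mus musculus) for antiproliferative activity, read by CCK-8 assay, with a stated time of 48 h (on this read-out lower numbers stand for stronger inhibition and higher numbers for weaker inhibition), and in that test compound 1 gives only a limit, > 10000 nM. This is the limit of > 10000 nM in this assay, at which 1 of the 2 values shown sits, so compound 1 stands at a limit and no exact number is known for it. Compound 2 `COc1ccc(/C=C\c2cc(OC)c(OC)c(OC)c2)cc1OCc1ccc(CO)cc1` differs from compound 1 in one place, and in this assay compound 2 gives 5700 nM. That step is an at least 1.7-fold lower number from compound 1 to compound 2 (0.24 log units; that floor lies within the scatter).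

Compound 3 `COc1ccc(/C=C\c2cc(OC)c(OC)c(OC)c2)cc1OCc1ccc(CN2CCCCC2C(=O)NCCN)cc1` has not yet been measured. It differs from compound 1 in a single place: 2-((2-aminoethyl)carbamoyl)piperidin-1-yl in place of 2-carboxy-4-hydroxypyrrolidin-1-yl on a saturated chain carbon bound to an aromatic carbon. For the measured compounds named here, the only measured step that bears on this change is the one from compound 1 to compound 2, and its floor lies within the scatter, so no shift beyond the scatter can be read from it. Compound 3 is therefore expected to give about 8000 nM, within a range from 2000 nM to 30000 nM. The expected step is an at least 1.2-fold lower number from compound 1 to compound 3 (0.09 log units; that floor lies within the scatter).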

Compound 3, half-maximal inhibitory concentration: > 10000 nM
Compound 3: only a limit was reported; the forecaster's own chance of this, stated with the estimate: 45%; middle value at least 1.2-fold (0.09 log units) away from the limit.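

In this assay compound 3 gives > 10000 nM, which is a limit of the assay and not a number. Compound 1 and compound 3 both stand at limits, so the step between them cannot be read, and the exchange of 2-carboxy-4-hydroxypyrrolidin-1-yl for 2-((2-aminoethyl)carbamoyl)piperidin-1-yl has no size that can be stated: the limit of > 10000 nM in this assay, at which 2 of the 3 values shown sit. Putting the new group in place of hydroxy gives an at least 1.7-fold higher number from compound 2 to compound 3 (0.24 log units; that floor lies within the scatter), so this second large group on a saturated chain carbon bound to an aromatic carbon also shows no readable shift beyond the scatter.

The compounds shown leave open how far the true values lie past the limit. They also leave open whether a smaller group, such as a dimethylamino group in place of hydroxy, would give a number that can be read.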